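The source may report more compounds than this note shows. Statements on the series, on what has been measured and on what is new or still open speak of the compounds shown alone.

Measured so far in a functional assay on L1210 cells (Mus musculus) for antiproliferative activity, read by cell counting, with a stated time of 2 days; a higher number here means a weaker inhibitor, a lower number a stronger inhibitor:
- compound 1 `COc1cc(C(=O)c2sc(N3CCCC3)nc2N)cc(OC)c1OC` gives 370 nM
- compound 2 `COc1ccc(C(=O)c2sc(N3CCCC3)nc2N)cc1OC` gives 60000 nM

Compound 2 holds the higher of the two numbers and is the weaker inhibitor of the pair, by a gap beyond the scatter. Compound 3 `COc1ccc(C(=O)c2sc(N3CCCC3)nc2N)cc1` is not yet measured. It differs from compound 2 by hydrogen in place of methoxy on an aromatic carbon. Among the measured compounds shown here, the one measured step of the same kind (a 160-fold higher number from compound 1 to compound 2 (2.21 log units; beyond the scatter)) is large and beyond the scatter. It is a single step, and it started from a far lower number, whereas compound 2 already stands high at 60000 nM on this scale. A repeat of that size is therefore not assumed. Expected here is a small rise, not beyond the scatter (a 1.3-fold higher number from compound 2 to compound 3 (0.12 log units; within the scatter)). The estimate for compound 3 is 80000 nM (range 25000 nM to 200000 nM).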

Compound 3, half-maximal inhibitory concentration: > 200000 nM
Compound 3: a limit, no number; the forecaster's own chance of this, stated with the estimate: 35%; at least 2.5-fold (0.39 log units) between middle value and limit.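

In this assay compound 3 gives > 200000 nM, which is a limit of the assay and not a number. The step of an at least 3.3-fold higher number from compound 2 to compound 3 (0.52 log units; beyond the scatter) shows that hydrogen in place of this methoxy, ortho to a methoxy group and meta to a large group, still moves the number beyond the scatter, even from the high standing of compound 2, as the earlier step of a 160-fold higher number from compound 1 to compound 2 (2.21 log units; beyond the scatter) did from a far lower one. The full size of the new step stays unread for compound 3, so the two steps cannot be ranked by size: the limit of > 200000 nM in this assay, at which 1 of the 3 values shown sits.

The compounds shown leave open whether a hydroxyl, an ethoxy or a fluorine at this place would keep the number nearer that of compound 2. They also leave open what replacing the methoxy that remains in compound 3 would do.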